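The compounds below may be only part of what the source reports. "The series", "measured", "known", "first", "only" and "open" are said of these compounds alone.

In a functional assay on HeLa cells (Homo sapiens) for inhibition, read by trypan blue exclusion, with a stated time of 72 h (on this read-out higher numbers stand for weaker inhibition of growth and lower numbers for stronger inhibition of growth), compound 2 `CC/C(=C(\c1ccccc1)c1ccc(NC(=O)C(C)C)cc1)c1ccc(Cl)cc1Cl` gives 3300 nM. Compound 3 `CC/C(=C(/c1ccc(NC(=O)C(C)C)cc1)c1ccc(OC)cc1)c1ccc(Cl)cc1Cl` gives 2200 nM, and a 1.5-fold lower number from compound 2 to compound 3 (0.18 log units; within the scatter) lies within the scatter, so the two cannot be told apart. Compound 1 `CC/C(=C(\c1ccccc1)c1ccc(NC(=O)C(C)C)cc1)c1ccccc1` gives > 30000 nM, which is a limit of the assay. With 2,4-dichlorophenyl in place of phenyl, the series shows an at least 9.0-fold lower number from compound 1 to compound 2 (0.95 log units; beyond the scatter), a step beyond the scatter whose size rests on that limit.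

Compound 4 `CC/C(=C(/c1ccccc1)c1ccc(NC(=O)C(C)C)cc1)c1ccc(Cl)cc1Cl` has the same atoms and bonds as compound 2 and differs only in configuration as drawn: the two compounds have the same atoms and bonds and differ only in configuration as drawn: 1 of 1 stereo elements differ; a double bond is drawn Z in compound 2 and E in compound 4. Neither measured step changes the configuration of a double bond, so neither measures this change directly. The step to compound 3, a 1.5-fold lower number from compound 2 to compound 3 (0.18 log units; within the scatter), shows that one added methoxy left the value within the scatter. The step to compound 2, an at least 9.0-fold lower number from compound 1 to compound 2 (0.95 log units; beyond the scatter), shows that a single change can also move a value well beyond it. The data therefore give no firm direction, and no step beyond the scatter is expected, though the uncertainty stays wide. The expected change is a 1.2-fold higher number from compound 2 to compound 4 (0.08 log units; within the scatter). For compound 4 the estimated value is 4000 nM, within an expected range from 1300 nM to 15000 nM.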

Compound 4, concentration for 50% growth inhibition: 8200 nM
Compound 4: middle estimate off by 2.1-fold (0.31 log units), on the low side; the range from low to high includes it.
By their numbers in this assay, from the lowest: compounds 3 and 2 (each within the scatter of the next); then compound 4. At a limit, above all of these: compound 1.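

In this assay, configuration alone moves the number, with a 2.5-fold higher number from compound 2 to compound 4 (0.40 log units; beyond the scatter), a modest step. The earlier steps shown here each exchanged a group, phenyl for 2,4-dichlorophenyl or hydrogen for methoxy, whereas this one neither adds nor removes an atom, so the shift can be tied to the double bond as drawn and to nothing else: the fact that compounds 2 and 4 differ only in the configuration as drawn. In this pair, which carries the 2,4-dichlorophenyl group on both sides, the Z drawing of compound 2 gives the lower number than the E drawing of compound 4, so the double-bond configuration has to be counted as a change in its own right in this series, though the finding rests on this single pair.

Compound 1 is known only as a limit, so it offers no firm baseline for judging configuration without the two chlorines: the limit of > 30000 nM in this assay, at which 1 of the 4 values shown sits. Also open, on these data alone, is whether the configuration step keeps its size and direction in the methoxy-bearing compound 3, or when the amide on the shared core gives way to an amine or a carboxylic acid.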